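The source may hold more compounds than are shown below. What is called first, only, known or untested is meant among the compounds shown, and "the series" means these compounds.

Measured compounds:
compound 1 `CN(C(=S)SCc1ccc(C(=O)Nc2ccccc2N)cc1)c1cccnc1` gives 26.5% in a functional assay on A-375 cells (Homo sapiens) for antiproliferative activity, read by CCK-8 assay, with a stated time of 72 h, tested at 2 uM; on this read-out higher numbers stand for a stronger effect at the one concentration tested and lower numbers for a weaker effect
compound 2 `Nc1ccccc1NC(=O)c1ccc(CSC(=S)N2CCCc3ccccc32)cc1` gives 26.5% in this assay
compound 3 `Nc1ccccc1NC(=O)c1ccc(CSC(=S)N2CCN(c3ccc(F)cc3)CC2)cc1` gives 20.9% in this assay

Compound 3 stands at the lower end of these three numbers, but its gaps to compound 1 and to compound 2 are both within the scatter, so the three compounds cannot be told apart on this read-out. Compound 4 `Nc1ccccc1NC(=O)c1ccc(CSC(=S)N2CCN(c3ccccc3F)CC2)cc1` differs from compound 3 by 2-fluorophenyl in place of 4-fluorophenyl on an amine nitrogen in a ring.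

Among the compounds with values here, only one measured step exists, no change at the digits printed from compound 1 to compound 2 (within the scatter), and it alters the group on the thiocarbonyl carbon rather than the group on the amine nitrogen in the ring; it therefore says nothing direct about the fluorophenyl change. Within the data shown here, no measured step concerns a fluorophenyl substituent. With every measured value within the scatter of every other, the expectation for compound 4 is a step of a number 1.1 percentage points higher from compound 3 to compound 4 (within the scatter), that is none beyond the scatter. Compound 4 is thus estimated at 22%, with a range from 12% to 34%.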

Compound 4, a percentage reported as inhibition, at one concentration (the size of the read-out at that concentration, not a potency): 18.7%
The estimate for compound 4 lay 3.3 percentage points above the measured number; measured number inside the range.
By their numbers in this assay, from the lowest: compounds 4, 3, 1 and 2 (each within the scatter of the next).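

In this assay, 2-fluorophenyl in place of 4-fluorophenyl on the amine nitrogen in the ring gives a number 2.2 percentage points lower from compound 3 to compound 4 (within the scatter). Within the data shown here, this is the first step measured at this position, and it shows that, at the one concentration tested, the place of the fluorine on the aromatic ring does not separate these two compounds on this read-out. No measurement at hand speaks to why the two compounds behave alike.

Going by these compounds, compound 3 and compound 4 both carry a fluorophenyl group on this nitrogen, so it remains open whether another group there, such as 3-fluorophenyl, methoxyphenyl, a pyridine ring or a simple methyl, would move the number beyond the scatter. Also open, on these data alone, is whether compound 3 and compound 4 would stay together at another concentration or in another cell line.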